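Exchanging one substituted phenyl for another on a shared core

The source may hold more compounds than are shown below. What is called first, only, known or untested is meant among the compounds shown, and "the series" means these compounds.

In a functional assay on A549 cells (Homo sapiens) for cytotoxicity, read by MTT assay, with a stated time of 72 h (a higher number here means a weaker inhibitor, a lower number a stronger inhibitor), compound 3 `CNC(=O)c1cc(Oc2ccc(C3=NNC(c4ccc(Cl)c(Cl)c4)C3)cc2)ccn1` gives 10700 nM as its reading. Compound 1 `CNC(=O)c1cc(Oc2ccc(C3=NNC(c4ccc([N+](=O)[O-])cc4)C3)cc2)ccn1` gives 19500 nM and so sits within the scatter of compound 3, which means neither can be ranked ahead of the other. Compound 2 `CNC(=O)c1cc(Oc2ccc(C3=NNC(c4cccc([N+](=O)[O-])c4)C3)cc2)ccn1` has "not determined" (no result reported) as its entry and adds nothing to the comparison. Compound 4 `CNC(=O)c1cc(Oc2ccc(C3=NNC(c4ccc(F)cc4)C3)cc2)ccn1` has not yet been measured. It keeps the shared core and carries 4-fluorophenyl in place of 3,4-dichlorophenyl on a saturated ring carbon. Among the measured compounds shown here, the one measured step (a 1.8-fold lower number from compound 1 to compound 3 (0.26 log units; within the scatter)) changes a group on that same ring carbon and stays within the scatter. A single step is thin evidence, but it gives no reason to expect a large shift in this assay or any particular direction. The estimated change is a 1.1-fold higher number from compound 3 to compound 4 (0.05 log units; within the scatter) and is expected to stay within the scatter. For compound 4 the estimated value is 12000 nM with an expected range from 5000 nM to 30000 nM in this measurement.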

Compound 4, half-maximal inhibitory concentration: 15100 nM
The estimate for compound 4 lay 1.3-fold (0.10 log units) below the measured number, and the stated range covers the measured number.
By their numbers in this assay, from the lowest: compounds 3, 4 and 1 (each within the scatter of the next).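

Three different substituted phenyl groups on the saturated ring carbon now give readings that cannot be told apart. In this assay the exchange of 3,4-dichlorophenyl for 4-fluorophenyl gives a 1.4-fold higher number from compound 3 to compound 4 (0.15 log units; within the scatter) and stays as small as the earlier step, while the exchange of nitro for fluoro on an aromatic carbon gives a 1.3-fold lower number from compound 1 to compound 4 (0.11 log units; within the scatter) and is just as small. Nothing at hand explains these readings.

Going by these compounds, compound 2 has no result, so steps involving it cannot be read, and whether the place of the nitro group on the phenyl ring matters stays unknown. All the groups shown at this position are substituted phenyl rings, so it remains open whether an amine or a carboxylic acid on that ring would move the number beyond the scatter.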